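A Methoxy-for-Methyl Swap Carried onto a Second Core

A few compounds are considered here, and "the series" means these few. Any claim that something is new, unique, unknown or untested is made for them only; others in the source may bear on it.

Of the compounds shown here, three have so far been tested in a functional assay on T47D cells (Homo sapiens) for cytotoxicity, with a stated time of 72 h, tested at 10 ug/mL; a lower number here means a weaker effect, a higher number a stronger effect of the compound at the concentration tested. Compound 1 `Cc1ccc(N2CCN/C2=N\N)cc1` gives 12% in this assay. Compound 2 `COc1ccc(N2CCN/C2=N\N)cc1` differs from it by methoxy in place of methyl on an aromatic carbon, and in this assay compound 2 gives 17%. The step between them is a number 5 percentage points higher from compound 1 to compound 2 (within the scatter). Compound 3 `Cc1ccccc1N1CCn2c1n[nH]c(=O)c2=O` is built on a different core, and the difference between the two cores is not broken down here. In this assay compound 3 gives 0%, the lowest of the three numbers, with its nearest neighbour being compound 1 and its furthest being compound 2.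

Compound 4 `COc1ccccc1N1CCn2c1n[nH]c(=O)c2=O` awaits measurement in this assay. It differs from compound 3 by methoxy in place of methyl on an aromatic carbon. Within the data shown here, this is the same kind of change as the one from compound 1 to compound 2, but not the same change: in the first pair the place is para to a group of 7 heavy atoms, whereas in compound 4 the place is ortho to a large group.

Among the measured compounds shown here, the one measured instance of this kind of change, a number 5 percentage points higher from compound 1 to compound 2 (within the scatter), stayed within the scatter, and this is the only basis for an expectation. The step of a number 5 percentage points higher from compound 3 to compound 4 (within the scatter) is therefore expected to be small as well. Compound 4 is expected to give about 5% in this assay, most likely between 0% and 20%.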

Compound 4, a percentage reported as inhibition, at one concentration (the size of the read-out at that concentration, not a potency): 1%
For compound 4 the middle estimate is 4 percentage points above the measured one, and the stated range covers the measured number.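

In this assay, the methoxy-for-methyl change on the second core gives a number 1 percentage points higher from compound 3 to compound 4 (within the scatter), and set beside the first core, the two steps do not differ beyond what repeated measurements would allow: the same change on two cores in this assay, a number 5 percentage points higher (within the scatter) from compound 1 to compound 2 and a number 1 percentage points higher (within the scatter) from compound 3 to compound 4, 4 percentage points apart, within the scatter of two such steps. Within these four compounds, then, the change carries from one core to the other as a small step on both, with neither step large enough to be read as an effect. This does not show that the change is without consequence in general, since compound 3 gives 0% and compound 4 gives 1%, both close to zero at a single concentration, and the place on the aromatic ring is not the same in the two pairs, so the agreement rests on two steps that are not strict copies of each other.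

The compounds shown carry only methyl and methoxy on the aromatic ring, which leaves open how a chlorine, a nitrile, an amine or a carboxylic acid there would read on either core. They also leave open whether methyl and methoxy would behave alike if they stood at one and the same place on both cores.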